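The source may hold more compounds than are shown below. What is called first, only, known or untested is meant among the compounds shown, and "the series" means these compounds.

For the measured compounds named here, compound 2 `CCN1CCC(NC(=O)c2nc(C(C)C)n3ccccc23)CC1` stands highest of the two numbers so far in a functional assay on CHO cells for agonist activity at 5-hydroxytryptamine receptor 4 (Homo sapiens), read by a luciferase reporter and cAMP accumulation, with a stated time of 4 h (a higher number here means a larger maximal response, a lower number a smaller maximal response), where compound 2 gives 100%. Going by the values given here, its nearest neighbour is compound 1 `COCCCN1CCC(O)(CNC(=O)c2nc(C(C)C)n3ccccc23)CC1`, which in this assay gives 41%, a gap beyond the usual scatter; the two structures differ in several places, so the pair defines no single step. Compound 3 `CC(C)c1nc(C(=O)NC2CCN(CC(C)(C)O)CC2)c2ccccn12` follows from compound 2 by one change: 1-hydroxy-1-methylethyl in place of methyl on a saturated chain carbon bound to an amine nitrogen in a ring. Among the compounds with values here, no measured step isolates this change, so only an expectation can be offered. The expected step is a number 20 percentage points lower from compound 2 to compound 3 (beyond the scatter), downward and modest, possibly no more than the scatter. Compound 3 is estimated at 80%, with a range from 45% to 100%.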

Compound 3, largest response reached (Emax), in percent of the reference or control that the assay uses: 80%
Beside the measured number, compound 3's estimate shows no gap at the digits printed, within the range that was stated.
By their numbers in this assay, from the lowest: compound 1; then compound 3; then compound 2.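

In this assay, for the compounds shown here, the change from methyl to 1-hydroxy-1-methylethyl on a saturated chain carbon bound to an amine nitrogen in a ring gives a number 20 percentage points lower from compound 2 to compound 3 (beyond the scatter) as the first measured step at this position. This place therefore takes the larger group with its hydrogen-bond donor and acceptor, and compound 3 keeps a response of 80% in this assay. No measurement shown accounts for the step. The compounds shown leave open whether the hydroxyl or the added carbons carry this step, which 2-methylpropyl at this place would separate. From the compounds shown here alone, how an amine or a carboxylic acid there would read also remains open.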